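The source may report more compounds than this note shows. Statements on the series, on what has been measured and on what is new or still open speak of the compounds shown alone.

Measured compounds:
- Compound 1, `COC(=O)C1=C(C)N=C(C)/C(=C(\O)OC)C1c1cccc(OC(C)=O)c1`, in a functional assay (muscle tissue) with Cavia porcellus as the target (a higher number here means that more compound is needed for the effect, a lower number that less compound is needed), gives 6030 nM
- Compound 2, `COC(=O)C1=C(C)N=C(C)/C(=C(\O)OC)C1c1ccccc1I`, in this assay gives 46.8 nM
- Compound 3, `COC(=O)C1=C(C)N=C(C)/C(=C(\O)OC)C1c1ccccc1C#N`, in this assay gives 15.9 nM

Compound 3 has the lowest number of the three in this assay. Its nearest neighbour is compound 2, with a 2.9-fold lower number from compound 2 to compound 3 (0.47 log units; beyond the scatter), and compound 1 lies far off from it, as the two values for compound 1 and compound 3 show.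

Compound 4, `COC(=O)C1=C(C)N=C(C)/C(=C(\O)OC)C1c1cccc(C)c1`, is not yet measured. It differs from compound 3 in one place: 3-methylphenyl in place of 2-cyanophenyl on a saturated ring carbon.

Among the measured compounds shown here, only one measured step is known, a 2.9-fold lower number from compound 2 to compound 3 (0.47 log units; beyond the scatter), and it exchanges one group for another while keeping the 2-position of the phenyl ring. It does not speak to moving a substituent to the 3-position. What bears on that is the pair compound 1 and compound 3: compound 1, which carries a 3-substituted phenyl, gives 6030 nM in this assay, while compound 3 gives 15.9 nM. On that basis the number for compound 4 is expected to rise well beyond the scatter, with a 75-fold higher number from compound 3 to compound 4 (1.88 log units; beyond the scatter). The estimate for compound 4 in this assay is 1200 nM, within a range from 150 nM to 8000 nM.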

Compound 4, half-maximal effective concentration: 110 nM
Compound 4: middle estimate off by 11-fold (1.04 log units), on the high side; measured number below the stated range.
By their numbers in this assay, from the lowest: compound 3; then compound 2; then compound 4; then compound 1.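

Methyl in place of acetoxy on an aromatic carbon gives a 55-fold lower number from compound 1 to compound 4 (1.74 log units; beyond the scatter) in this assay. This step changes the group and leaves its place as it is. With 3-methylphenyl in place of the earlier rings, the steps are only modest, a 6.9-fold higher number from compound 3 to compound 4 (0.84 log units; beyond the scatter) and a 2.4-fold higher number from compound 2 to compound 4 (0.37 log units; beyond the scatter), so this group leaves the number much nearer to those of the 2-cyanophenyl and 2-iodophenyl compounds than to that of compound 1. Nothing at hand accounts for these steps.

The compounds shown leave open how far the rise from compound 3 to compound 4 belongs to the group and how far to its place, which a 2-methylphenyl or a 3-cyanophenyl compound would separate. On these data alone, how an amine or a carboxylic acid on this ring would fare in this assay also stays open.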